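This account rests on a few compounds, and the source may have more. Where it says the series, first, only, none or still open, it means among the compounds named here.

Compound 1, `CCN(CC)S(=O)(=O)NC(=O)Nc1c(C(C)C)cccc1C(C)C`, and compound 2, `CC(C)c1cccc(C(C)C)c1NC(=O)NS(=O)(=O)N(CC1CCCO1)CC1CCCO1`, share a core with two isopropyl groups on an aromatic ring and a sulfonyl-bearing side chain. In an assay on liver for inhibition of sterol O-acyltransferase 1 (Rattus norvegicus), using microsomes (on this read-out higher numbers stand for weaker inhibition and lower numbers for stronger inhibition), compound 1 gives 2500 nM. In this assay compound 2 gives 1700 nM. Compound 3, `CC(C)c1cccc(C(C)C)c1OC(=O)NS(=O)(=O)N1CCOCC1`, carries a morpholin-4-yl group on the sulfonyl sulfur, and in this assay compound 3 is reported only as a limit of the assay, > 100000 nM, which is the limit of > 100000 nM in this assay, at which 1 of the 3 values shown sits. Compound 4, `CC(C)c1cccc(C(C)C)c1OC(=O)NS(=O)(=O)N(C(C)C)C(C)C`, differs from compound 3 by a change on the sulfonyl sulfur whose other neighbour is an amide-type nitrogen: diisopropylamino in place of morpholin-4-yl on a sulfonyl sulfur. No measured step is shown for this change, so for compound 4 in this assay only a modest expected gain an at least 1.6-fold lower number from compound 3 to compound 4 (0.22 log units; that floor lies within the scatter) is assumed, remaining weak. The expected value for compound 4 in this assay is 60000 nM, in the range 10000 nM to 300000 nM.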

Compound 4, half-maximal inhibitory concentration: 15000 nM
Beside the measured number, compound 4's estimate is 4.0-fold (0.60 log units) above it; the range from low to high includes it.
By their numbers in this assay, from the lowest: compounds 2 and 1 (each within the scatter of the next); then compound 4. At a limit, above all of these: compound 3.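

On a sulfonyl sulfur whose other neighbour is an amide-type nitrogen, the group matters in this assay: diisopropylamino in place of morpholin-4-yl gives an at least 6.6-fold lower number from compound 3 to compound 4 (0.82 log units; beyond the scatter). Compound 3 is reported only as a limit, so this step is a floor and not a full size: the limit of > 100000 nM in this assay, at which 1 of the 4 values shown sits. The compounds shown leave open whether piperidin-1-yl, a ring without the oxygen of morpholin-4-yl, would also lower the number. They also leave open whether a smaller open-chain amine such as dimethylamino would do so.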